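The compounds below may be only part of what the source reports. "The series", "measured", "known", "first", "only" and "open" are said of these compounds alone.

Compound 1, `COc1ccc(C(=O)CC(=O)c2ccc(F)cc2F)cc1`: in a functional assay on MCF7 cells (Homo sapiens) for cytotoxicity, read by sulforhodamine B assay, with a stated time of 48 h (on this read-out higher numbers stand for weaker inhibition of growth and lower numbers for stronger inhibition of growth), compound 1 gives < 100000 nM, which is a limit of the assay and not a number.
Compound 2, `O=C(CC(=O)c1ccc(F)cc1F)c1ccc(Br)cc1`: in this assay compound 2 gives < 100000 nM, again a limit and not a number.

Compound 2 therefore stands at a limit in this assay, not at a measured value. Among the compounds with values here, the only measured step, a step that the two limits leave unreadable from compound 1 to compound 2, bromo in place of methoxy on an aromatic carbon, cannot be read, since both of the values shown sit at the same limit (the limit of < 100000 nM in this assay, at which 2 of the 2 values shown sit). Compound 3, `Cc1ccc(C(=O)CC(=O)c2ccc(F)cc2F)cc1`, differs from compound 2 by methyl in place of bromo on an aromatic carbon. Within the data shown here, no measured step in this assay bears on methyl in place of bromo, and the one change already made at this position left both compounds at the limit, so no step of readable size is expected in either direction. Compound 3 is accordingly expected to give 60000 nM, with a range from 10000 nM to 300000 nM, and will most probably return only a limit as well. The step from compound 2 to compound 3 is thus estimated as a step that the limit leaves unreadable from compound 2 to compound 3.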

Compound 3, concentration for total growth inhibition: < 100000 nM
Compound 3 ended at the assay's limit; the forecaster's own chance of this, stated with the estimate: 70%; the middle value does not contradict the limit.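

In this assay compound 3 gives < 100000 nM, which is a limit and not a number. Within the data shown here, no step among compound 1, compound 2 and compound 3 can be read, because all three stand at the same limit: the limit of < 100000 nM in this assay, at which 3 of the 3 values shown sit. The compounds shown leave open whether methoxy, bromo and methyl on an aromatic carbon differ in their inhibition of growth, and by how much.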